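Swapping the basic amine on the chain of compound 1

The compounds below may be only part of what the source reports. "The series", "measured", "known", "first", "only" and "open" are said of these compounds alone.

Compound 1 `O=c1cc(-c2ccccc2)oc2cc(OCc3ccccc3)c(OCCCCN3CCCCC3)c(O)c12` is the reference here. In a functional assay on BCG823 cells (Homo sapiens) for antiproliferative activity, read by MTT assay, with a stated time of 48 h (a lower number here means a stronger inhibitor, a higher number a weaker inhibitor), compound 1 gives 3000 nM, the lowest of the three numbers recorded. Compound 2 `O=c1cc(-c2ccccc2)oc2cc(O)c(OCCCCN3CCCCC3)c(O)c12` gives 52700 nM and compound 3 `COc1cc2oc(-c3ccccc3)cc(=O)c2c(O)c1OCCCCN1CCCCC1` gives 21900 nM, so compound 1 sits well ahead of both: an 18-fold higher number from compound 1 to compound 2 (1.24 log units; beyond the scatter), and a 7.3-fold higher number from compound 1 to compound 3 (0.86 log units; beyond the scatter). Between the two weaker compounds, a 2.4-fold lower number from compound 2 to compound 3 (0.38 log units; beyond the scatter).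

Compound 4 `CCN(CC)CCCCOc1c(OCc2ccccc2)cc2oc(-c3ccccc3)cc(=O)c2c1O` differs from compound 1 in a single respect: diethylamino in place of piperidin-1-yl on a saturated chain carbon, four bonds along the chain from an oxygen on an aromatic ring. Among the compounds with values here, every measured step so far touches the groups on the aromatic oxygens, whether the benzyl is lost or the hydrogen exchanged for methyl, and none of them alters the amine at the end of the chain. The measured steps therefore give no direct guidance on this change; what they do show is that the benzyl and the amine-bearing chain are both present in compound 1 and in compound 4 alike, so the ground on which compound 1 rests is preserved. On that basis the step from compound 1 to compound 4 is expected to be small, with a 1.3-fold higher number from compound 1 to compound 4 (0.12 log units; within the scatter) lying within the usual scatter. Compound 4 is accordingly estimated at 4000 nM, with a range from 1500 nM to 12000 nM.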

Compound 4, half-maximal inhibitory concentration: 4200 nM
Beside the measured number, compound 4's estimate is 1.1-fold (0.02 log units) below it; the range from low to high includes it.
By their numbers in this assay, from the lowest: compounds 1 and 4 (each within the scatter of the next); then compound 3; then compound 2.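

In this assay, within the data shown here, the first measured change at the end of the chain, diethylamino in place of piperidin-1-yl, gives a 1.4-fold higher number from compound 1 to compound 4 (0.15 log units; within the scatter) and so leaves the two compounds within the scatter of each other. The earlier steps shown here all touched the groups on the aromatic oxygens and all lay beyond the scatter, while this pair shows that, with the benzyl kept, the amine can lose its six-membered ring and give up one heavy atom without a readable step. Nothing measured here bears on why these two amines read alike.

From the compounds shown here alone, whether that tolerance extends to a morpholin-4-yl, pyrrolidin-1-yl or dimethylamino group at the end of the chain, or to a shorter or longer chain carrying the amine, stays open. Also open, going by these compounds, is whether diethylamino would read the same with the hydrogen of compound 2 or the methyl of compound 3 on the aromatic oxygen in place of the benzyl.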